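A few compounds are considered here, and "the series" means these few. Any claim that something is new, unique, unknown or untested is made for them only; others in the source may bear on it.

Measured in a functional assay on HCT-116 cells (Homo sapiens), read by MTT assay, with a stated time of 72 h; on this read-out lower numbers stand for stronger inhibition and higher numbers for weaker inhibition:
compound 1, `Cc1ncnc2c1c(I)cn2[C@@H]1O[C@H](CO)[C@@H](O)[C@H]1O`, gives 4720 nM.
compound 2, `Cc1ncnc2c1c(-c1ccoc1)cn2[C@@H]1O[C@H](CO)[C@@H](O)[C@H]1O`, gives > 20000 nM, which is a limit of the assay and not a number.
compound 3, `Cc1nc(N)c2c(I)cn([C@@H]3O[C@H](CO)[C@@H](O)[C@H]3O)c2n1`, gives > 20000 nM, which is a limit of the assay and not a number.

Compounds 1 and 2 share one core and differ in a single place: furan-3-yl in place of iodo on an aromatic carbon. On this change there is an at least 4.2-fold higher number from compound 1 to compound 2 (0.62 log units; beyond the scatter). The size of that step is known only as a lower bound because of the limit of > 20000 nM in this assay, at which 2 of the 3 values shown sit. Compound 3 carries a different core; the difference between the two cores is not broken down here.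

Compound 4, `Cc1nc(N)c2c(-c3ccoc3)cn([C@@H]3O[C@H](CO)[C@@H](O)[C@H]3O)c2n1`, has not yet been measured in this assay. It stands to compound 3 as compound 2 stands to compound 1: furan-3-yl in place of iodo on an aromatic carbon. The surroundings of the place are the same in both pairs, so this is the same change made on the second core. Of compound 3 only a limit is known, so the starting point of the new step is itself open-ended. The one earlier example of this change gave a weakening of the number, and nothing among the compounds shown points the other way. For compound 4 in this assay the step from compound 3 is expected to be a step that the limit leaves unreadable from compound 3 to compound 4, resting on the earlier step of an at least 4.2-fold higher number from compound 1 to compound 2 (0.62 log units; beyond the scatter). Compound 4 is therefore estimated at 50000 nM, and most likely the assay will again report only a limit for it.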

Compound 4, half-maximal inhibitory concentration: > 20000 nM
Compound 4 gave a limit, no number (the forecaster's own chance of this, stated with the estimate: 90%); the middle value does not contradict the limit.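

In this assay compound 4 gives > 20000 nM, which is a limit of the assay and not a number. No step between compound 3 and compound 4 can be read, because both compounds sit at the same limit: the limit of > 20000 nM in this assay, at which 3 of the 4 values shown sit.

The compounds shown leave open how furan-3-yl in place of iodo on an aromatic carbon acts on the core of compound 3, and how far compound 3 and compound 4 lie beyond that limit.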